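The source may hold more compounds than are shown below. What is called first, only, known or untested is meant among the compounds shown, and "the series" means these compounds.

Three amides sharing one core have been measured in a functional assay on MCF7 cells (Homo sapiens) for antiproliferative activity, read by MTT assay, with a stated time of 72 h; a higher number here means a weaker inhibitor, a lower number a stronger inhibitor. Compound 1 `O=C(Nc1ccc(Cl)c(-c2nnc3c(Cl)cccn23)c1)c1ccc(C(F)(F)F)cc1Cl` gives 81600 nM. Compound 3 `O=C(Nc1ccc(Cl)c(-c2nnc3c(Cl)cccn23)c1)c1ccc(Cl)cc1Cl` gives 78200 nM, the lowest of the two numbers, though a 1.0-fold lower number from compound 1 to compound 3 (0.02 log units; within the scatter) lies within the scatter. Compound 2 `O=C(Nc1ccc(Cl)c(-c2nnc3c(Cl)cccn23)c1)c1ccc(F)cc1Cl` reaches only the limit of this assay, > 100000 nM. That limit, (the limit of > 100000 nM in this assay, at which 1 of the 3 values shown sits), sets a floor under an at least 1.2-fold higher number from compound 1 to compound 2 (0.08 log units; that floor lies within the scatter) and under an at least 1.2-fold lower number from compound 2 to compound 3 (0.10 log units; that floor lies within the scatter). Compound 4 `CS(=O)(=O)c1ccc(C(=O)Nc2ccc(Cl)c(-c3nnc4c(Cl)cccn34)c2)c(Cl)c1` differs from compound 3 in one place: methylsulfonyl in place of chloro on an aromatic carbon. Going by the values given here, the measured steps exchanged one halogen or trifluoromethyl for another at that place and moved nothing beyond the scatter; the methylsulfonyl change is of a different kind and has no measured counterpart here. The step expected for compound 4 is a 1.3-fold higher number from compound 3 to compound 4 (0.11 log units; within the scatter), with the limit a real possibility. The estimate for compound 4 is 100000 nM, between 40000 nM and 250000 nM.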

Compound 4, half-maximal inhibitory concentration: > 100000 nM
Compound 4 was reported as a limit (the forecaster's own chance of this, stated with the estimate: 45%); the middle value sits exactly at the limit.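

In this assay this position now carries methylsulfonyl, a group of another kind than a halogen or trifluoromethyl, and the change gives an at least 1.2-fold higher number from compound 3 to compound 4 (0.10 log units; that floor lies within the scatter) and an at least 1.2-fold higher number from compound 1 to compound 4 (0.08 log units; that floor lies within the scatter) with neither floor establishing a step beyond the scatter. The result for compound 4 is a limit, and the step between compound 2 and compound 4 cannot be read. Two of the compounds now stand at such a limit: the limit of > 100000 nM in this assay, at which 2 of the 4 values shown sit. As far as these compounds go, it remains open whether an amine, a carboxylic acid or a longer chain at this position would move the number beyond the scatter.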